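The source may hold more compounds than are shown below. What is called first, only, known or untested is meant among the compounds shown, and "the series" means these compounds.

Of the compounds shown here, three built on one shared core have been tested in a functional assay on HeLa cells (Homo sapiens) for cytotoxicity, read by MTT assay; on this read-out higher numbers stand for weaker inhibition and lower numbers for stronger inhibition. Compound 1 `CC(C)=CC[C@@H](OC(=O)c1ccoc1)C1=CC(=O)c2c(O)ccc(O)c2C1=O` gives only a limit of the assay, > 100000 nM. Compound 2 `CC(C)=CC[C@@H](OC[C@H](C)O)C1=CC(=O)c2c(O)ccc(O)c2C1=O` gives 40300 nM. Compound 3 `CC(C)=CC[C@@H](OC(=O)CC(C)(O)c1ccccc1)C1=CC(=O)c2c(O)ccc(O)c2C1=O` gives 85700 nM, the highest of the two numbers obtained. The step of an at least 2.4-fold lower number from compound 1 to compound 2 (0.39 log units; beyond the scatter) was at least modest, whereas the step of an at least 1.1-fold lower number from compound 1 to compound 3 (0.06 log units; that floor lies within the scatter) has a floor that lies within the scatter. Compound 4 `CC[C@](C)(O)CC(=O)O[C@H](CC=C(C)C)C1=CC(=O)c2c(O)ccc(O)c2C1=O` differs from compound 3 in one place: 1-hydroxy-1-methylpropyl in place of 1-hydroxy-1-phenylethyl on a saturated chain carbon bound to a carbonyl carbon. The change sits in the same side chain that the step of an at least 1.1-fold lower number from compound 1 to compound 3 (0.06 log units; that floor lies within the scatter) varied with little effect, so for compound 4 no shift beyond the scatter is expected: a 1.1-fold higher number from compound 3 to compound 4 (0.02 log units; within the scatter). Compound 4 is accordingly estimated at about 90000 nM, between 30000 nM and 300000 nM.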

Compound 4, half-maximal inhibitory concentration: 30200 nM
Compound 4: middle estimate off by 3.0-fold (0.47 log units), on the high side, within the range that was stated.
By their numbers in this assay, from the lowest: compounds 4 and 2 (each within the scatter of the next); then compound 3. At a limit, above all of these: compound 1.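

In this assay, the side chain on a saturated chain carbon bound to a carbonyl carbon is not silent: 1-hydroxy-1-methylpropyl in place of 1-hydroxy-1-phenylethyl gives a 2.8-fold lower number from compound 3 to compound 4 (0.45 log units; beyond the scatter). The step of a 1.3-fold lower number from compound 2 to compound 4 (0.13 log units; within the scatter) shows no separation between these two side chains. The step of an at least 3.3-fold lower number from compound 1 to compound 4 (0.51 log units; beyond the scatter) is only a floor, as one end of it is a limit of the assay: the limit of > 100000 nM in this assay, at which 1 of the 4 values shown sits.

On these data alone, whether removing the aromatic ring or adding the ethyl and methyl groups matters more stays open. How an amine or a carboxylic acid at this place would read is also unknown.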